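The compounds below may be only part of what the source reports. "The series", "measured", "known", "first", "only" and "open" are said of these compounds alone.

The measured compounds:
Compound 1, `Cn1c(C(=O)Nc2ccccc2)cc2ccccc21`, gives 100000000 nM in an assay on isolated protein for inhibition of Amine oxidase [flavin-containing] A (Homo sapiens); on this read-out higher numbers stand for weaker inhibition and lower numbers for stronger inhibition.
Compound 2, `CN(C(=O)c1cc2ccccc2n1C)c1ccccc1`, gives 15000000 nM in this assay.
Compound 3, `O=C(NCCCCc1ccccc1)c1ccc[nH]1`, gives 55000000 nM in this assay.

Compound 2 differs from compound 1 in one place only: methyl in place of hydrogen on an amide-type nitrogen. That single change produced the step of a 6.7-fold lower number from compound 1 to compound 2 (0.82 log units; beyond the scatter). Compound 3 is built on a different core; the difference between the two cores is not broken down here. Its number stands close to that of compound 1 and higher than that of compound 2.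

The unmeasured compound 4, `CN(CCCCc1ccccc1)C(=O)c1ccc[nH]1`, differs from compound 3 by methyl in place of hydrogen on an amide-type nitrogen. For the measured compounds named here, this is the same kind of change as the one from compound 1 to compound 2, but not the same: in compound 1 the amide-type nitrogen has aromatic carbon and carbonyl carbon as its other neighbours, whereas in compound 3 they are carbonyl carbon and saturated chain carbon. Going by the values given here, the only guide to the size of the step is a 6.7-fold lower number from compound 1 to compound 2 (0.82 log units; beyond the scatter). Given the different surroundings, compound 4 is expected to move by a somewhat smaller step of a 3.7-fold lower number from compound 3 to compound 4 (0.56 log units; beyond the scatter) in this assay. Compound 4 is therefore estimated at 15000000 nM, with a likely range from 4000000 nM to 60000000 nM.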

Compound 4, inhibition constant: 89900000 nM
Estimate against measurement, compound 4: 6.0-fold (0.78 log units) below; the whole stated range lies below it.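

Putting methyl in place of hydrogen on the amide-type nitrogen gives a 1.6-fold higher number from compound 3 to compound 4 (0.21 log units; within the scatter) in this assay, so on this core the change has no effect that can be told from the scatter. The step seen on one core therefore does not carry over in size to the other, and it cannot be assumed for a new core in this series: the same change on two cores in this assay, a 6.7-fold lower number (0.82 log units; beyond the scatter) from compound 1 to compound 2 and a 1.6-fold higher number (0.21 log units; within the scatter) from compound 3 to compound 4, 11-fold (1.04 log units) apart, beyond the scatter of two such steps

For the compounds shown here, with only two pairs, this does not show which difference matters, whether the saturated chain carbon on the nitrogen of compound 3, the aromatic carbon on the nitrogen of compound 1, or some other part of the two cores. The compounds shown leave open whether ethyl, a group larger than methyl, on the same nitrogen would give a clear step on either core. Going by these compounds alone, they also leave open how a longer chain in place of the one in compound 3, or a third core carrying the same methyl change, would behave.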